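A Methyl Swap at the Weak End of the Scale

The source may report more compounds than this note shows. Statements on the series, on what has been measured and on what is new or still open speak of the compounds shown alone.

For the measured compounds named here, in a functional assay on MGC-803 cells (Homo sapiens) for inhibition, read by MTT assay, with a stated time of 48 h (a higher number here means a weaker inhibitor, a lower number a stronger inhibitor), compound 2 `COc1cc(NCc2cccc(O)c2)cc(OC)c1OC` gives 57600 nM as the only true number so far. Compound 1 `COc1cc(NCc2ccc(Br)cc2)cc(OC)c1OC` reads > 80000 nM as a limit of the assay and not a number.

The next change 4-methylphenyl in place of 3-hydroxyphenyl on a saturated chain carbon bound to a nitrogen on an aromatic ring puts 4-methylphenyl in place of 3-hydroxyphenyl on a saturated chain carbon bound to a nitrogen on an aromatic ring, giving compound 3 `COc1cc(NCc2ccc(C)cc2)cc(OC)c1OC` for testing. Going by the values given here, the one measured step bearing on this change is an at least 1.3-fold lower number from compound 1 to compound 2 (0.14 log units; that floor lies within the scatter) at the same place, and that floor lies within the scatter. With so little to go on, no shift beyond the scatter is expected. The estimated step of a 1.0-fold higher number from compound 2 to compound 3 (0.02 log units; within the scatter) stays small in either direction. For compound 3 the estimate is 60000 nM with an expected range from 25000 nM to 110000 nM and a reading that is only a limit would fit this expectation too.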

Compound 3, half-maximal inhibitory concentration: > 80000 nM
Compound 3 was reported as a limit; the forecaster's own chance of this, stated with the estimate: 40%; middle value at least 1.3-fold (0.12 log units) away from the limit.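

Putting 4-methylphenyl in place of 3-hydroxyphenyl on this saturated chain carbon gives an at least 1.3-fold higher number from compound 2 to compound 3 (0.14 log units; that floor lies within the scatter), so only a floor is known, and the real size of the step stays hidden. For the compounds shown here, compound 3 reads as a limit, as compound 1 does, which leaves compound 2, the one compound here with 3-hydroxyphenyl, as the only one with a true number, while the step for methyl in place of bromo cannot be read. Every comparison at this place therefore runs into the same ceiling at the weak end of the scale: the limit of > 80000 nM in this assay, at which 2 of the 3 values shown sit.

From the compounds shown here alone, whether any group at this place can bring a reading clearly beyond the scatter remains open. An amine or a carboxylic acid on this phenyl ring would test that, as would a longer chain between the ring and the nitrogen.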